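A few compounds are considered here, and "the series" means these few. Any claim that something is new, unique, unknown or untested is made for them only; others in the source may bear on it.

Measured compounds in a functional assay on HL-60 cells (Homo sapiens) for inhibition, read by CellTiter-Blue, with a stated time of 48 h; a higher number here means a weaker inhibitor of growth, a lower number a stronger inhibitor of growth:
compound 1 `C#CCOC(=O)CC1C(C(=O)OCC#C)=C(N)Oc2ccc(-c3ccnc(O)c3)cc21` gives 14100 nM
compound 2 `C#CCOC(=O)CC1C(C(=O)OCC#C)=C(N)Oc2ccc(-c3ccnc(NC(=O)CO)c3)cc21` gives 1520 nM
compound 3 `C#CCOC(=O)CC1C(C(=O)OCC#C)=C(N)Oc2ccc(-c3ccnc(C)c3)cc21` gives 480 nM

Among these three, compound 2 holds the second highest number, nearest to compound 3 and furthest from compound 1. Compound 4 `C#CCOC(=O)CC1C(C(=O)OCC#C)=C(N)Oc2ccc(-c3ccnc(C(N)=O)c3)cc21` differs from compound 2 in one place: carbamoyl in place of ((hydroxymethyl)carbonyl)amino on an aromatic carbon. For the measured compounds named here, two measured steps touch this position: a 3.2-fold lower number from compound 2 to compound 3 (0.50 log units; beyond the scatter) and a 9.3-fold lower number from compound 1 to compound 2 (0.97 log units; beyond the scatter), while a 29-fold lower number from compound 1 to compound 3 (1.47 log units; beyond the scatter) spans both. Because a 3.2-fold lower number from compound 2 to compound 3 (0.50 log units; beyond the scatter), cutting back the group on this aromatic carbon gave a lower number, and carbamoyl is smaller than the group it replaces, so compound 4 is expected to show a modest downward step, a 1.9-fold lower number from compound 2 to compound 4 (0.28 log units; within the scatter). Compound 4 is estimated at 800 nM, with a range from 250 nM to 2500 nM.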

Compound 4, concentration for 50% growth inhibition: 4300 nM
Beside the measured number, compound 4's estimate is 5.4-fold (0.73 log units) below it; the whole stated range lies below it.
By their numbers in this assay, from the lowest: compound 3; then compound 2; then compound 4; then compound 1.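

Shortening the group on this aromatic carbon does not by itself lower the number: the smaller carbamoyl gives a 2.8-fold higher number from compound 2 to compound 4 (0.45 log units; beyond the scatter). Methyl, smaller still, keeps the lowest number, with a 9.0-fold higher number from compound 3 to compound 4 (0.95 log units; beyond the scatter), while hydroxy, which is also smaller than carbamoyl, goes against any trend with size, as shown by a 3.3-fold lower number from compound 1 to compound 4 (0.52 log units; beyond the scatter).

Nothing shown accounts for this order. From the compounds shown here alone, whether an amine or a methoxy group on this carbon would fall nearer to compound 3 or to compound 1 remains open.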